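The source may hold more compounds than are shown below. What is called first, only, known or untested is meant among the compounds shown, and "the series" means these compounds.

In a functional assay on ZR-75-1 cells (Homo sapiens) for inhibition, read by sulforhodamine B assay (a higher number here means a weaker inhibitor of growth, a lower number a stronger inhibitor of growth), compound 1 (`Oc1cccc2[nH]c(-c3ccc(-c4ccc(-c5ccc(F)cc5)cc4)cc3)nc12`) gives 6320 nM and compound 2 (`Oc1cccc2[nH]c(-c3ccc(-c4ccc(-c5ccc(OC(F)(F)F)cc5)cc4)cc3)nc12`) gives 3800 nM. Within the data shown here, compound 2 therefore stands within the scatter of compound 1, the only other compound measured, and the two cannot be ranked. Compound 3 (`Oc1ccc(-c2ccc(-c3ccc(-c4nc5c(O)cccc5[nH]4)cc3)cc2)cc1`) has not yet been measured. It carries hydrogen in place of trifluoromethyl on an oxygen on an aromatic ring, so trifluoromethoxy gives way to hydroxy: hydrogen in place of trifluoromethyl on an oxygen on an aromatic ring. Among the measured compounds shown here, only one measured step bears on this change, and it does so indirectly. That step, a 1.7-fold lower number from compound 1 to compound 2 (0.22 log units; within the scatter), put trifluoromethoxy in place of fluoro on an aromatic carbon. For the measured compounds named here, no measured compound carries the hydroxy group, so the data offer no direct guide to its effect and no direction for the change. With the exchange between compound 1 and compound 2 giving only a 1.7-fold lower number from compound 1 to compound 2 (0.22 log units; within the scatter), no shift beyond the scatter is expected here. The expected size of the change is a 1.1-fold higher number from compound 2 to compound 3 (0.02 log units; within the scatter). Compound 3 is estimated at 4000 nM, with an expected range of 1500 nM to 11000 nM.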

Compound 3, concentration for 50% growth inhibition: 2650 nM
Beside the measured number, compound 3's estimate is 1.5-fold (0.18 log units) above it, within the range that was stated.
By their numbers in this assay, from the lowest: compounds 3, 2 and 1 (each within the scatter of the next, the first and the last beyond it).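

In this assay, putting hydrogen in place of trifluoromethyl on an oxygen on an aromatic ring gives a step that cannot be ranked (a 1.4-fold lower number from compound 2 to compound 3 (0.16 log units; within the scatter)), so trifluoromethoxy and hydroxy are not told apart at this place in the shared core. Among these compounds, compound 3 also supplies the only step in this set that clears the scatter, a modest one for hydroxy in place of fluoro on an aromatic carbon (a 2.4-fold lower number from compound 1 to compound 3 (0.38 log units; beyond the scatter)), although neither of the steps that involve compound 2 does so; the hydroxy compound can thus be separated from the fluoro compound, while the trifluoromethoxy compound sits within the scatter of both. No measurement of any other kind is at hand to account for these steps.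

On these data alone, how a methoxy group, an amine or a carboxylic acid at this same place would read stays open, and so does whether any group there could carry the growth inhibition well beyond the narrow span seen so far. The three compounds also share the rest of the core unchanged, so they say nothing about how much of the activity depends on the hydroxy group on the other end of the molecule.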